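A few compounds are considered here, and "the series" means these few. Any claim that something is new, unique, unknown or untested is made for them only; others in the source may bear on it.

Three compounds built on one shared core have numbers in a functional assay on A-375 cells (Homo sapiens) for cytotoxicity, read by CCK-8 assay, with a stated time of 24 h; a lower number here means a stronger inhibitor, a higher number a weaker inhibitor. Compound 1 `COc1cccc(-c2nc(N)c(Oc3ccccc3OC)c(Cl)n2)c1` gives 24600 nM, compound 2 `COc1ccccc1Oc1c(N)nc(-c2ccc(F)cc2)nc1Cl` gives 28200 nM, and compound 3 `COc1ccccc1Oc1c(N)nc(-c2ccc(Cl)cc2)nc1Cl` gives 1030 nM. Compound 2 cannot be told apart from compound 1, as a 1.1-fold higher number from compound 1 to compound 2 (0.06 log units; within the scatter) shows, while compound 3 stands clearly lower, with a 27-fold lower number from compound 2 to compound 3 (1.44 log units; beyond the scatter).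

Compound 4 `COc1ccccc1Oc1c(N)nc(-c2ccc(F)cc2)nc1OCCO` keeps the 4-fluorophenyl group of compound 2 and differs elsewhere: 2-hydroxyethoxy in place of chloro on an aromatic carbon. Put simply, 2-hydroxyethoxy takes the place of chloro on an aromatic carbon, next to the ring nitrogen.

Among the measured compounds shown here, no measured step touches this position. All three measured steps change the group where compound 2 carries its 4-fluorophenyl, so they bear on the new change only indirectly. They do show how far one swap can move the number in this assay: a 24-fold lower number from compound 1 to compound 3 (1.38 log units; beyond the scatter) is large, whereas a 1.1-fold higher number from compound 1 to compound 2 (0.06 log units; within the scatter) is not.

For the measured compounds named here, with no measured example of this swap, the data give no direction, so the central expectation is no change beyond the scatter, held with a wide margin on both sides. The estimated step is a 1.1-fold higher number from compound 2 to compound 4 (0.03 log units; within the scatter). For compound 4 the expected value is 30000 nM, with an estimated range of 8000 nM to 100000 nM.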

Compound 4, half-maximal inhibitory concentration: 15900 nM
Beside the measured number, compound 4's estimate is 1.9-fold (0.28 log units) above it; the range from low to high includes it.
By their numbers in this assay, from the lowest: compound 3; then compounds 4, 1 and 2 (each within the scatter of the next).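

Among the compounds shown here, this is the first measured change at the position next to the ring nitrogen: in this assay, 2-hydroxyethoxy in place of chloro gives a 1.8-fold lower number from compound 2 to compound 4 (0.25 log units; within the scatter), so compound 2 and compound 4 cannot be told apart. For the compounds shown here, the entering group has 4 heavy atoms and 1 hydrogen-bond donor, while chloro has 1 heavy atom and no donor, yet this exchange produces no step as large as a 27-fold lower number from compound 2 to compound 3 (1.44 log units; beyond the scatter) seen at the 4-fluorophenyl group. No measured evidence here explains why the number stays within the scatter.

The compounds shown leave open whether 2-hydroxyethoxy would have the same small effect alongside the 4-chlorophenyl group of compound 3, which gives 1030 nM. They also leave open what an amine, a carboxylic acid or a longer chain ending in hydroxyl would do at this position, since one replacement for chloro cannot show how far the number can move there.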